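Fluoro in place of hydrogen on two related cores

The compounds below may be only part of what the source reports. "The series", "measured", "known", "first", "only" and "open" are said of these compounds alone.

Measured compounds:
Compound 1, `Clc1ncnc2ncn(Cc3ccccc3)c12`, gives in an assay on isolated protein for inhibition of RAC-alpha serine/threonine-protein kinase (Homo sapiens), tested at 30 uM (on this read-out lower numbers stand for less inhibition and higher numbers for more inhibition at the one concentration tested (going by the name of the read-out)), a value of 0%.
Compound 2, `Fc1ccc(Cn2cnc3ncnc(Cl)c32)cc1`, gives in this assay a value of 0%.
Compound 3, `c1ccc(Cn2cnc3c(Sc4ccccc4)ncnc32)cc1`, gives in this assay a value of 1%.

All three measured numbers sit at the bottom of the scale, and none of the three is separated from the others by more than the usual scatter. Within the data shown here, the one counted change among them is fluoro in place of hydrogen on an aromatic carbon, and that step reads no change at the digits printed from compound 1 to compound 2 (within the scatter). Compound 3 carries a different core from compound 1; how the two cores differ is not broken down here.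

Compound 4, `Fc1ccc(Cn2cnc3c(Sc4ccccc4)ncnc32)cc1`, is not yet measured. It arises from compound 3 by fluoro in place of hydrogen on an aromatic carbon, the same change as from compound 1 to compound 2, at a place described in the same words. Because the matched step gave no change at the digits printed from compound 1 to compound 2 (within the scatter), and because compound 3 itself gives 1%, the expected step is no change at the digits printed from compound 3 to compound 4 (within the scatter), that is, no change beyond the scatter. Compound 4 is therefore estimated at 1%, with an expected range from 0% to 8%.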

Compound 4, a percentage reported as inhibition, at one concentration (the size of the read-out at that concentration, not a potency): 13%
The estimate for compound 4 lay 12 percentage points below the measured number, outside the stated range (above it).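

In this assay, fluoro in place of hydrogen on the benzyl ring reads a number 12 percentage points higher from compound 3 to compound 4 (beyond the scatter), whereas on the core of compound 1 the same change reads no change at the digits printed from compound 1 to compound 2 (within the scatter). Set side by side, the two steps cannot be told apart, so the series gives no firm sign that the outcome of this change depends on the core: the same change on two cores in this assay, no change at the digits printed (within the scatter) from compound 1 to compound 2 and a number 12 percentage points higher (beyond the scatter) from compound 3 to compound 4, 12 percentage points apart, within the scatter of two such steps. Among these compounds, this does not show that the change carries over unchanged either, since each core offers only one matched pair, and compound 4, at 13%, is a reading at a single concentration and not a potency.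

The compounds shown leave open whether a larger difference between the two steps would emerge on further cores, and whether a methoxy group or a carboxylic acid in place of the fluoro of 4-fluorobenzyl would move this read-out. Also open, as far as these compounds go, is how an amine in place of the chloro group of compound 2 would read in this assay.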